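A few compounds are considered here, and "the series" means these few. Any claim that something is new, unique, unknown or untested is made for them only; others in the source may bear on it.

Three compounds have been measured in a functional assay on Malme-3M cells (Homo sapiens) for cytotoxicity, read by sulforhodamine B assay, with a stated time of 48 h, tested at 1 uM; on this read-out higher numbers stand for a weaker effect at the one concentration tested and lower numbers for a stronger effect:

Compound 1, `COc1cc(-c2cc(/C=C/C(=O)c3ccc(Cl)c(Cl)c3)[nH]n2)cc(OC)c1OC`, gives 95%.
Compound 2, `COc1ccc(-c2cc(/C=C/C(=O)c3cc(OC)c(OC)c(OC)c3)[nH]n2)cc1OC`, gives 93%.
Compound 3, `COc1ccc(C(=O)/C=C/c2cc(-c3cc(OC)c(OC)c(OC)c3)n[nH]2)cc1`, gives 93%.

Compound 3 stands level with compound 2 at the digits printed, and these two together form the lowest pair of the three numbers. Among the measured compounds shown here, the only step measured between compounds that differ in one place is a number 2 percentage points lower from compound 1 to compound 3 (within the scatter), so the swap of one aryl group on the carbonyl carbon left the read-out within the scatter.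

The next compound, compound 4, `COc1cc(-c2cc(/C=C/C(=O)c3ccc(F)c(F)c3)[nH]n2)cc(OC)c1OC`, is drawn from compound 3 by a change at that same place: 3,4-difluorophenyl in place of 4-methoxyphenyl on a carbonyl carbon.

For the measured compounds named here, the one step that bears on this change is a number 2 percentage points lower from compound 1 to compound 3 (within the scatter), since it also exchanged the aryl group on the carbonyl carbon while the rest of the molecule was held fixed, and it produced nothing beyond the scatter. Going by the values given here, compound 2 carries a different aryl group on the carbonyl carbon together with a different group on the other end, so its value shows only that it sits beside compound 3 at the digits printed. On this basis compound 4 is expected to show no step beyond the scatter, a number 1 percentage points higher from compound 3 to compound 4 (within the scatter). Compound 4 is therefore estimated at 94%, with a range from 84% to 103%.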

Compound 4, a percentage reported as activity, at one concentration (the size of the read-out at that concentration, not a potency): 97%
Estimate against measurement, compound 4: 3 percentage points below; the range from low to high includes it.
By their numbers in this assay, from the lowest: compounds 2, 3, 1 and 4 (each within the scatter of the next).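

In this assay the change to 3,4-difluorophenyl on a carbonyl carbon is a number 4 percentage points higher from compound 3 to compound 4 (within the scatter) when 4-methoxyphenyl leaves, and a number 2 percentage points higher from compound 1 to compound 4 (within the scatter) when 3,4-dichlorophenyl leaves. Compounds 1, 3 and 4 now give three aryl groups at this place with the rest of the molecule held fixed, and all the steps among them stay within the scatter, so neither exchanging the methoxy group for halogens nor exchanging chlorine for fluorine separates these compounds on this read-out. Nothing shown offers an explanation of these values.

The compounds shown leave open whether a carboxylic acid or an amine on the aryl group, or a saturated ring such as cyclohexyl in its place on the carbonyl carbon, would give a step beyond the scatter. They also leave open how compounds 1, 3 and 4 would compare at any other concentration, since a read-out at a single concentration is not a potency and gives no ranking of them beyond what the printed values show.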